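Ether substituent survey at the aromatic oxygen

The source may hold more compounds than are shown below. What is called first, only, known or untested is meant among the compounds shown, and "the series" means these compounds.

Of the compounds shown here, two have been measured in an assay on isolated protein for inhibition of mitogen-activated protein kinase kinase kinase 11 (Homo sapiens), tested at 1 uM; on this read-out higher numbers stand for more inhibition at the one concentration tested (going by the name of the read-out) and lower numbers for less inhibition. Compound 1 `O=C1NCc2c1c1c(c3c2c2ccccc2n3CCO)CCc2cc(OC3CCCC3)ccc2-1` carries a cyclopentyl group on the aromatic oxygen and gives 32%. Compound 2 `O=C1NCc2c1c1c(c3c2c2ccccc2n3CCO)CCc2cc(OCC3CC3)ccc2-1`, in which cyclopropylmethyl replaces cyclopentyl, gives 32%. The step of no change at the digits printed from compound 1 to compound 2 (within the scatter) thus lies within the scatter, and compound 2 stands level with compound 1 on this read-out.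

Compound 3 `O=C1NCc2c1c1c(c3c2c2ccccc2n3CCO)CCc2cc(OC3CCCCC3)ccc2-1` is the next member: cyclohexyl in place of cyclopropylmethyl on an oxygen on an aromatic ring. Among the compounds with values here, the only step that bears on it is the one from compound 1 to compound 2, which was flat, so a change in ring size of the group on the aromatic oxygen has not moved the read-out so far. On that basis no step beyond the scatter is expected for compound 3 either, and the expected step of a number 1 percentage points lower from compound 2 to compound 3 (within the scatter) is close to zero. The value of compound 3 in this assay is estimated at 31%, within a range of 16% to 46%.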

Compound 3, a percentage reported as inhibition, at one concentration (the size of the read-out at that concentration, not a potency): 4%
For compound 3 the middle estimate is 27 percentage points above the measured one; the whole stated range lies above it.
By their numbers in this assay, from the lowest: compound 3; then compounds 1 and 2 (each within the scatter of the next).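

In this assay cyclohexyl in place of cyclopentyl on an oxygen on an aromatic ring gives a number 28 percentage points lower from compound 1 to compound 3 (beyond the scatter) and cyclohexyl in place of cyclopropylmethyl gives a number 28 percentage points lower from compound 2 to compound 3 (beyond the scatter) in this short ether set. The flat first step therefore does not extend to every group at this place: the read-out does respond to what sits on the oxygen, and going from cyclopentyl to cyclohexyl alone is enough to show it. No measurement at hand accounts for the drop.

Open, on these data alone, is whether the drop belongs to cyclohexyl alone or continues to a larger ring such as cycloheptyl. Also open, as far as these compounds go, is whether a plain methyl, a longer straight chain or a chain ending in an amine on this oxygen would sit level with compound 1 and compound 2 or fall with compound 3.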